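The source may report more compounds than this note shows. Statements on the series, on what has been measured and on what is new or still open speak of the compounds shown alone.

Compound 1: `N#CC1=C(N)Oc2c(c3nc4ccccc4nc3c3ccccc23)C12C(=O)N(Cc1cnnn1-c1ccc(F)cc1)c1ccccc12` — > 50000 nM
Compound 2: `N#CC1=C(N)Oc2c(N)cc3nc4ccccc4nc3c2C12C(=O)N(Cc1cnnn1-c1ccc(F)cc1)c1ccccc12` — > 50000 nM

Both compounds were tested in a functional assay on HCT-116 cells (Homo sapiens) for antiproliferative activity, read by MTT assay, with a stated time of 48 h; a higher number here means a weaker inhibitor, a lower number a stronger inhibitor. For compound 1 the reported value > 50000 nM is a limit of the assay rather than a number. For compound 2 the reported value > 50000 nM is likewise a limit. Compound 2 therefore stands at the limit of this assay, and it shares that position with the other compound, as the limit of > 50000 nM in this assay, at which 2 of the 2 values shown sit, shows; no measured number separates the two.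

Compound 3, `N#CC1=C(N)Oc2c(N)cc3nc4ccccc4nc3c2C12C(=O)N(Cc1cnnn1-c1ccccc1Br)c1ccccc12`, has not yet been tested. It differs from compound 2 in one place: 2-bromophenyl in place of 4-fluorophenyl on an aromatic nitrogen. Within the data shown here, no step between measured compounds is available for this change, so no size can be read from the data. With compound 2 at the limit in this assay, the most plausible outcome is that the step is none beyond the scatter and that compound 3 also reaches only a limit.

Compound 3 is expected to give about 60000 nM, within a range from 20000 nM to 200000 nM. That estimate corresponds to a step that the limit leaves unreadable from compound 2 to compound 3, which is expected to lie within the scatter.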

Compound 3, half-maximal inhibitory concentration: 12400 nM
For compound 3 the middle estimate is 4.8-fold (0.68 log units) above the measured one; the whole stated range lies above it.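

In this assay, putting 2-bromophenyl in place of 4-fluorophenyl on the aromatic nitrogen of the five-membered ring gives an at least 4.0-fold lower number from compound 2 to compound 3 (0.60 log units; beyond the scatter). The two earlier compounds both sat at a limit and could not show that the group at this position can shift the read-out at all; this pair shows that it can, at least on this core. The exchange leaves the heavy-atom count and the single six-membered aromatic ring unchanged, yet the size of the step can be stated only as a lower bound because compound 2 stands at a limit: the limit of > 50000 nM in this assay, at which 2 of the 3 values shown sit.

The change swaps fluorine for bromine and moves the halogen on the ring in one step, so the compounds shown cannot tell which of the two matters, and a pair such as 4-bromophenyl and 2-fluorophenyl, or plain phenyl as a reference, would be needed to separate them. From the compounds shown here alone, it also remains open whether 2-bromophenyl would have a similar effect on the core of compound 1, and whether a larger group on the same ring, such as 2-methoxyphenyl, would lower the number further.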